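The compounds below may be only part of what the source reports. "The series", "measured", "known", "first", "only" and "open" are said of these compounds alone.

In a functional assay on HCT-116 cells (Homo sapiens) for inhibition, read by sulforhodamine B assay, with a stated time of 48 h (a higher number here means a weaker inhibitor, a lower number a stronger inhibitor), three compounds built on a shared core have been measured: compound 1 (`COc1cc2c(cc1CCC(C)C)C(=O)C[C@@H](c1ccc(O)cc1)O2`) gives 34300 nM, compound 2 (`COc1cc2c(cc1CC1OC1(C)C)C(=O)C[C@@H](c1ccc(O)cc1)O2`) gives 29000 nM, and compound 3 (`COc1cc2c(cc1CC=C(C)C)/C(=N/NC(N)=O)C[C@@H](c1ccc(O)cc1)O2`) gives 24300 nM. Compound 3 lies within the usual scatter of both others, so it does not stand apart from them.

Compound 4 (`COc1cc2c(cc1CC=C(C)C)/C(=N/O)C[C@@H](c1ccc(O)cc1)O2`) differs from compound 3 in one place: hydroxy in place of ureido on a double-bonded nitrogen. In words, hydroxy takes the place of ureido on a double-bonded nitrogen.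

Within the data shown here, the only measured step between two compounds that differ in one place is a 1.2-fold lower number from compound 1 to compound 2 (0.07 log units; within the scatter). That step lies within the scatter, but it concerns the side chain and not the double-bonded nitrogen, so it bears on this change only loosely. Among the measured compounds shown here, no measured pair isolates a change at that nitrogen.

Resting on that step and on compound 3 at 24300 nM, no shift beyond the scatter is expected in this assay. The expected step is a 1.2-fold lower number from compound 3 to compound 4 (0.08 log units; within the scatter), an estimate with an uncertain direction. For compound 4 the estimated value is 20000 nM, with an expected range of 8000 nM to 42000 nM.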

Compound 4, half-maximal inhibitory concentration: 29700 nM
Compound 4: middle estimate off by 1.5-fold (0.17 log units), on the low side; measured number inside the range.
By their numbers in this assay, from the lowest: compounds 3, 2, 4 and 1 (each within the scatter of the next).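

In this assay, among these compounds, the first change at this position gives a 1.2-fold higher number from compound 3 to compound 4 (0.09 log units; within the scatter), with hydroxy in place of ureido on a double-bonded nitrogen. Going from ureido, with 4 heavy atoms and 2 hydrogen-bond donors, to hydroxy, with 1 heavy atom and 1 hydrogen-bond donor, therefore moves the number no further than the scatter. No measurement here offers an explanation for this flat result.

Going by these compounds, whether an amine or a methoxy group on that nitrogen would move the number beyond the scatter remains open. Also open, on these data alone, is how compound 3 and compound 4 would compare with a partner that has the same side chain and a plain carbonyl in place of the carbon-nitrogen double bond.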